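The source may hold more compounds than are shown below. What is called first, only, known or untested is meant among the compounds shown, and "the series" means these compounds.

Compound 1 `Fc1ccccc1-c1cc(COc2ccccc2-c2nc3ccccc3s2)on1` gives 18300 nM.
Compound 2 `COc1ccc(-c2cc(COc3ccccc3-c3nc4ccccc4s3)on2)cc1` gives 20700 nM.
Compound 3 `Clc1ccc(-c2cc(COc3ccccc3-c3nc4ccccc4s3)on2)cc1` gives 16500 nM.

In a functional assay on COLO 205 cells (Homo sapiens) for cytotoxicity, read by MTT assay, with a stated time of 24 h (on this read-out lower numbers stand for stronger inhibition and higher numbers for weaker inhibition), compound 3 has the lowest of the three numbers, yet the steps of a 1.1-fold lower number from compound 1 to compound 3 (0.04 log units; within the scatter) and a 1.3-fold lower number from compound 2 to compound 3 (0.10 log units; within the scatter) both lie within the scatter, so the three compounds cannot be told apart on these data. Compound 4 `Cc1ccc(-c2cc(COc3ccccc3-c3nc4ccccc4s3)on2)cc1` differs from compound 3 by methyl in place of chloro on an aromatic carbon. Within the data shown here, the steps that bear on this swap are a 1.1-fold higher number from compound 1 to compound 2 (0.05 log units; within the scatter), a 1.1-fold lower number from compound 1 to compound 3 (0.04 log units; within the scatter) and a 1.3-fold lower number from compound 2 to compound 3 (0.10 log units; within the scatter), each within the scatter, showing that exchanging the group on the outer ring has so far left the number unchanged. A further such exchange is therefore expected to give no step beyond the scatter. The expected change is a 1.1-fold higher number from compound 3 to compound 4 (0.03 log units; within the scatter). Compound 4 is estimated at 17500 nM, with a range from 9000 nM to 35000 nM.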

Compound 4, half-maximal inhibitory concentration: 14200 nM
Estimate against measurement, compound 4: 1.2-fold (0.09 log units) above, and the stated range covers the measured number.
By their numbers in this assay, from the lowest: compounds 4, 3, 1 and 2 (each within the scatter of the next).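

In this assay, methyl in place of chloro (a 1.2-fold lower number from compound 3 to compound 4 (0.07 log units; within the scatter)), methyl in place of methoxy (a 1.5-fold lower number from compound 2 to compound 4 (0.16 log units; within the scatter)) and 4-methylphenyl in place of 2-fluorophenyl (a 1.3-fold lower number from compound 1 to compound 4 (0.11 log units; within the scatter)) all leave the compounds indistinguishable. Methyl thus joins chloro and methoxy as a group whose exchange at this position, para to a large group, produces no step beyond the scatter. Nothing measured here bears on why the number stays so flat. On these data alone, whether an amine, a carboxylic acid or a longer chain at this position would move the number beyond the scatter stays open, as does the effect of changing the shared core.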